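The source may hold more compounds than are shown below. What is called first, only, known or untested is meant among the compounds shown, and "the series" means these compounds.

In an assay on isolated protein for inhibition of DNA topoisomerase 1 (Homo sapiens), with a stated time of 30 min, tested at 100 uM (a higher number here means more inhibition at the concentration tested (going by the name of the read-out), a lower number less inhibition), three compounds built on the same core have been tested. Compound 1 `Oc1ccc(-c2cc(-c3ccc(O)cc3)nc(-c3ccc(O)cc3)c2)cc1` gives 3.8%, compound 2 `Oc1ccc(-c2cc(-c3ccccc3O)cc(-c3ccccc3O)n2)cc1` gives 0.3%, and compound 3 `Oc1ccc(-c2cc(-c3cccc(O)c3)nc(-c3ccccc3O)c2)cc1` gives 1.5%. All three numbers are small, and the gaps separating compound 3 from compound 2 and from compound 1 both fall inside the usual scatter of this assay, so none of the three can be told apart from the others. Compound 4 `Oc1ccc(-c2cc(-c3cccc(O)c3)nc(-c3cccc(O)c3)c2)cc1` is not yet measured; it differs from compound 3 in one respect: 3-hydroxyphenyl in place of 2-hydroxyphenyl on an aromatic carbon. Within the data shown here, since no pair of measured compounds sets a step for this kind of swap, the expected change a number 0.5 percentage points higher from compound 3 to compound 4 (within the scatter) is none beyond the scatter. Compound 4 is therefore estimated to give about 2%, within a range from 0% to 8%.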

Compound 4, a percentage reported as inhibition, at one concentration (the size of the read-out at that concentration, not a potency): 0%
Beside the measured number, compound 4's estimate is 2 percentage points above it, within the range that was stated.
By their numbers in this assay, from the lowest: compounds 4, 2, 3 and 1 (each within the scatter of the next).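

Among these compounds, on the aromatic carbon next to the ring nitrogen, 3-hydroxyphenyl in place of 2-hydroxyphenyl gives the first comparison of compounds that differ in one place in this assay: a number 1.5 percentage points lower from compound 3 to compound 4 (within the scatter). This swap of one group for another with the same atoms therefore does not separate the two compounds. Nothing available explains the outcome at this position.

Still open, as far as these compounds go, is whether a group of another kind on this carbon, such as an amine or a carboxylic acid, would move the number beyond the scatter.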